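The compounds below may be only part of what the source reports. "The series", "measured", "known", "first", "only" and "open" are said of these compounds alone.

Series notes. The shared core is held constant and only the aryl group attached to it varies. Compound 1 `COc1cc(-c2ccnc3cc(-c4ccc(C(C)(C)C)cc4)nn23)cc(OC)c1OC` carries 4-(tert-butyl)phenyl; in a functional assay on MCF7 cells (Homo sapiens) for inhibition, read by CCK-8 assay, with a stated time of 48 h (on this read-out lower numbers stand for stronger inhibition and higher numbers for weaker inhibition), compound 1 gives only a limit, > 10000 nM, and no number (the limit of > 10000 nM in this assay, at which 1 of the 3 values shown sits). Compound 2 `COc1cc(-c2ccnc3cc(-c4ccc(C(C)=O)cc4)nn23)cc(OC)c1OC`, with 4-acetylphenyl, gives 5230 nM in this assay; the step is an at least 1.9-fold lower number from compound 1 to compound 2 (0.28 log units; that floor lies within the scatter). Compound 3 `COc1cc(-c2ccnc3cc(-c4ccc5ccn(C)c5c4)nn23)cc(OC)c1OC`, with 1-methyl-1H-indol-6-yl, gives 74 nM in this assay, the lowest number shown: compound 2 stands a 71-fold lower number from compound 2 to compound 3 (1.85 log units; beyond the scatter) away and compound 1 an at least 130-fold lower number from compound 1 to compound 3 (2.13 log units; beyond the scatter) away. Both steps are large and both exchange a substituted phenyl for the bicyclic group.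

Compound 4 `COc1cc(-c2ccnc3cc(-c4ccc5cnn(C)c5c4)nn23)cc(OC)c1OC` differs from compound 3 in one place: 1-methyl-1H-indazol-6-yl in place of 1-methyl-1H-indol-6-yl on an aromatic carbon. Among the compounds with values here, no measured step exchanges one bicyclic group for another; the two large steps concern the phenyl-to-indolyl exchange only, so they fix compound 3 as the reference but say nothing direct about this smaller change. The bicyclic frame, its methyl and the point of attachment are retained. A step within the scatter, or at most a modest one in either direction, is expected. The estimate for compound 4 in this assay is 120 nM, range 40 nM to 400 nM, which means an expected step of a 1.6-fold higher number from compound 3 to compound 4 (0.21 log units; within the scatter).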

Compound 4, half-maximal inhibitory concentration: 279 nM
Compound 4: middle estimate off by 2.3-fold (0.37 log units), on the low side; measured number inside the range.
By their numbers in this assay, from the lowest: compound 3; then compound 4; then compound 2. At a limit, above all of these: compound 1.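

Within the data shown here, compound 3 set the reference, but no earlier step exchanged one bicyclic group for another; in this assay, this position distinguishes 1-methyl-1H-indazol-6-yl from 1-methyl-1H-indol-6-yl, with a 3.8-fold higher number from compound 3 to compound 4 (0.58 log units; beyond the scatter), a modest step. The advantage over the substituted phenyls is not confined to the indolyl group, since the indazolyl group also gives large steps: a 19-fold lower number from compound 2 to compound 4 (1.27 log units; beyond the scatter), and an at least 35-fold lower number from compound 1 to compound 4 (1.55 log units; beyond the scatter). The second of these is only a floor, as compound 1 gives a limit and no number, > 10000 nM.

Nothing in the data given accounts for the higher number that comes with the second ring nitrogen. Open too is how this position would respond to a longer chain such as ethyl in place of the methyl on the bicyclic group, or to an amine or a carboxylic acid on its six-membered ring, as the compounds shown vary neither the methyl nor that ring.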